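Working notes on a small antiproliferative series

A few compounds are considered here, and "the series" means these few. Any claim that something is new, unique, unknown or untested is made for them only; others in the source may bear on it.

Measured so far in a functional assay on MGC-803 cells (Homo sapiens) for inhibition, read by MTT assay, with a stated time of 72 h; on this read-out higher numbers stand for weaker inhibition and lower numbers for stronger inhibition:
compound 1 `Cc1cc(Nc2ccn(Cc3cccc4ccccc34)n2)n2nc(SCc3ccc(Br)cc3)nc2n1`: 3240 nM
compound 2 `Cc1cc(Nc2cc(-c3ccccc3)[nH]n2)n2nc(SCc3c(Cl)cccc3Cl)nc2n1`: 5280 nM
compound 3 `CCCCCc1c(C)nc2nc(SCc3ccc(Cl)cc3)nn2c1Nc1cc(-c2ccccc2)[nH]n1`: 7140 nM

Compound 2 holds the second highest of the three numbers. Its nearest neighbour is compound 3, and compound 1 is the furthest off; both gaps lie within the scatter, so the three measured values cannot be ordered with any confidence.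

Compound 4 `Cc1cc(Nc2cc(-c3ccccc3)[nH]n2)n2nc(SCc3nc4ccccc4[nH]3)nc2n1` is not yet measured. It differs from compound 2 in one place: 1H-benzimidazol-2-yl in place of 2,6-dichlorophenyl on a saturated chain carbon bound to a sulfur. Among the measured compounds shown here, no pair of measured compounds isolates this change, so nothing shows which way it pulls. The expectation is therefore no step beyond the scatter, a 1.1-fold lower number from compound 2 to compound 4 (0.02 log units; within the scatter), with wide uncertainty in either direction.

Compound 4 is estimated at 5000 nM in this assay, in the range 1500 nM to 16000 nM.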

Compound 4, half-maximal inhibitory concentration: 1790 nM
Compound 4: middle estimate off by 2.8-fold (0.45 log units), on the high side; measured number inside the range.
By their numbers in this assay, from the lowest: compounds 4, 1, 2 and 3 (each within the scatter of the next, the first and the last beyond it).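

In this assay, among the compounds shown here, 1H-benzimidazol-2-yl in place of 2,6-dichlorophenyl on a saturated chain carbon bound to a sulfur gives a 2.9-fold lower number from compound 2 to compound 4 (0.47 log units; beyond the scatter), the only step so far read as beyond the scatter. The number at this position therefore responds to the group carried there, and a group with a hydrogen-bond donor and acceptor is accepted, though this rests on a single pair. Nothing at hand accounts for the step.

Open, as far as these compounds go, is whether the step follows the entering ring system or the loss of chlorine; unsubstituted phenyl or pyridin-2-yl in the same place would help separate the two. From the compounds shown here alone, whether the step carries over to the cores of compound 1 and compound 3 also remains open.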